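The compounds below may be only part of what the source reports. "The series", "measured", "known", "first", "only" and "open" are said of these compounds alone.

Measured compounds:
compound 1, `COc1ccc(-c2cc(=O)c3c(OC)cc(OC)cc3n2S(=O)(=O)c2ccc(F)cc2)cc1`, > 65500 nM
compound 2, `COc1ccc(-c2cc(=O)c3c(OC)cc(OC)cc3n2S(=O)(=O)c2cc(F)c(F)c(F)c2)cc1`, > 65500 nM
compound 3, `COc1ccc(-c2cc(=O)c3c(OC)cc(OC)cc3n2S(=O)(=O)c2c(F)c(F)c(F)c(F)c2F)cc1`, 4100 nM

The three compounds share one core and differ only in the ring attached to the sulfonyl sulfur. In a functional assay on SUP-B15 cells (Homo sapiens) for antiproliferative activity, with a stated time of 72 h (a higher number here means that more compound is needed for the effect, a lower number that less compound is needed), compound 1 reaches only the limit of the assay, > 65500 nM, not a number. In this assay compound 2 likewise stops at a limit, > 65500 nM. For the measured compounds named here, compound 3 is the one compound with a real number in this assay, namely 4100 nM, so it stands alone at the low end of what has been seen; the line the limit of > 65500 nM in this assay, at which 2 of the 3 values shown sit, marks where the other two sit.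

Compound 4, `COc1ccc(-c2cc(=O)c3c(OC)cc(OC)cc3n2S(=O)(=O)c2ccc(Br)cc2)cc1`, has not yet been measured. Compared with compound 3, the change is 4-bromophenyl in place of 2,3,4,5,6-pentafluorophenyl on a sulfonyl sulfur. Going by the values given here, the steps that bear on this are an at least 15-fold lower number from compound 1 to compound 3 (1.20 log units; beyond the scatter) and an at least 15-fold lower number from compound 2 to compound 3 (1.20 log units; beyond the scatter): each time the pentafluorophenyl entered in place of a less substituted ring, the number fell by a large amount. Removing the pentafluorophenyl again, for a ring carrying a single bromine, points the other way, and a large rise is expected, quite possibly back to the limit.

The estimate for compound 4 in this assay is 40000 nM, with a range from 8000 nM to 200000 nM, which means an expected step of a 9.8-fold higher number from compound 3 to compound 4 (0.99 log units; beyond the scatter) from compound 3 to compound 4.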

Compound 4, half-maximal effective concentration: 63800 nM
Compound 4: the middle estimate sits 1.6-fold (0.20 log units) below what was measured; the measured number falls inside the stated range.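

The step of a 16-fold higher number from compound 3 to compound 4 (1.19 log units; beyond the scatter) in this assay shows that a single bromine on the ring does not keep what the pentafluorophenyl group gives, so among the four rings on the sulfonyl sulfur, only pentafluorophenyl brings the number down clearly. For the compounds shown here, a swap of fluorine for bromine on this ring therefore does not recover the effect, and compound 3 remains the one compound that stands apart from the rest. Set against the two compounds without a real number, the data give only floors, an at least 1.0-fold lower number from compound 2 to compound 4 (0.01 log units; that floor lies within the scatter) and an at least 1.0-fold lower number from compound 1 to compound 4 (0.01 log units; that floor lies within the scatter) and neither floor lies beyond the scatter, so no real difference between compound 4 and either compound can be claimed. Compound 4 does give a real number, but it lies close to the line where those two compounds stop: the limit of > 65500 nM in this assay, at which 2 of the 4 values shown sit.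

Still open, going by these compounds, is whether a ring with other groups in place of the halogens, such as a trifluoromethyl, a nitrile, an amine or a carboxylic acid, would bring the number down as far as pentafluorophenyl does, or further. The compounds shown also leave open whether a ring with two or four fluorines would fall closer to compound 3 or to compound 2.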